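Chlorine added to the pyrimidine ring of a purine core

The compounds below may be only part of what the source reports. "The series", "measured", "known", "first", "only" and "open" are said of these compounds alone.

Three compounds have been measured in a functional assay on KM12 cells (Homo sapiens) for cytotoxicity, read by sulforhodamine B assay, with a stated time of 48 h; a lower number here means a stronger inhibitor of growth, a higher number a weaker inhibitor of growth:

Compound 1, `ClCc1cccc(Cn2cnc3ncnc(Cl)c32)c1`, gives 1860 nM
Compound 2, `ClCc1ccccc1Cn1cnc2ncnc(Cl)c21`, gives 3630 nM
Compound 3, `Nc1nc(Cl)c2ncn(Cc3cccc(CCl)c3)c2n1`, gives 3310 nM

The three numbers lie close together. Compound 2 is separated from compound 3 and from compound 1 by gaps that fall within the usual scatter of repeated measurements, so none of the three can be set above or below the others with confidence, and no single change between two measured compounds has been followed in this assay .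

The next compound, compound 4, `ClCc1ccccc1Cn1cnc2nc(Cl)nc(Cl)c21`, differs from compound 2 in one place: chloro in place of hydrogen on an aromatic carbon. The chlorine enters the six-membered aromatic ring with two nitrogen atoms, between two ring nitrogen atoms, meta to the chloro group already present, meta to one fused ring and para to the other.

Among the compounds with values here, with no measured pair showing what such a change does here, the expectation rests on the narrow spread of the three numbers and on the small size of the added group. The step from compound 2 to compound 4 is expected to be small, a 1.2-fold lower number from compound 2 to compound 4 (0.08 log units; within the scatter), likely staying within the scatter. Compound 4 is therefore estimated at 3000 nM, with a range from 1000 nM to 9000 nM.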

Compound 4, concentration for 50% growth inhibition: 11700 nM
Compound 4: middle estimate off by 3.9-fold (0.59 log units), on the low side, and the stated range ends below it.
By their numbers in this assay, from the lowest: compounds 1, 3 and 2 (each within the scatter of the next); then compound 4.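

Within the data shown here, this is the first single change that can be followed in this assay, and it gives a 3.2-fold higher number from compound 2 to compound 4 (0.51 log units; beyond the scatter) for chloro in place of hydrogen on an aromatic carbon. The three earlier compounds, whose numbers lie within the scatter of their neighbours, gave no sign that this position between two ring nitrogen atoms mattered; now a single added chlorine atom is seen to weaken growth inhibition by a modest but real step. Nothing available here accounts for this loss.

One pair cannot show whether the loss belongs to chlorine alone or to any group at this position, so an amine, a methoxy group or a fluorine atom there could give a different result. As far as these compounds go, it also remains open whether the same change would give a step of similar size on compound 1 , which differs from compound 2 in where its chloromethyl group sits.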